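The source may hold more compounds than are shown below. What is called first, only, known or untested is meant among the compounds shown, and "the series" means these compounds.

Working notes on the series.

Three compounds share one core. Compound 1 `CN(C(=O)NCCCOc1ccc2nc(O)ccc2c1)C1CCCCC1` gives 15% in a functional assay on the whole organism for inhibition, with Rattus norvegicus as the target, at a dose of 30 mg/kg by the oral route; a higher number here means more inhibition at the dose given (going by the name of the read-out), a lower number less inhibition. Compound 2 `O=C(NCCCOc1ccc2nc(O)ccc2c1)N(C1CCCCC1)C1CC1` gives 15%; the step of no change at the digits printed from compound 1 to compound 2 (within the scatter). Compound 3 `O=C(NCCCOc1ccc2nc(O)ccc2c1)N(C1CC1)[C@@H]1CCC[C@H]1O` gives 23%; the step of a number 8 percentage points higher from compound 2 to compound 3 (within the scatter). Compound 3 thus holds the highest of the three numbers, but both other values lie within the scatter of it, so no order among the three can be read from them.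

Compound 4 `O=C(NCCCOc1ccc2nc(O)ccc2c1)N(C1CC1)[C@@H]1CCCCC[C@H]1O` is not yet measured. Its change from compound 3 is 2-hydroxycycloheptyl in place of 2-hydroxycyclopentyl on an amide-type nitrogen. Going by the values given here, no measured step alters a hydroxy-bearing ring of this kind, so only the step from compound 2 to compound 3, which exchanged the saturated ring on the same nitrogen, bears on it at all, and that step stayed within the scatter. A step of a number 1 percentage points lower from compound 3 to compound 4 (within the scatter) is therefore expected, none beyond the scatter. Compound 4 is estimated at 22% in this assay, with a range from 8% to 36%.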

Compound 4, a percentage reported as inhibition, in the whole organism at one dose (the size of the read-out at that dose, not a potency): 0%
Compound 4: the middle estimate sits 22 percentage points above what was measured; measured number below the stated range.
By their numbers in this assay, from the lowest: compound 4; then compounds 1, 2 and 3 (each within the scatter of the next).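

Going by these compounds alone, this place on the amide-type nitrogen is the first to give a step beyond the scatter: in this assay the change to 2-hydroxycycloheptyl gives a number 23 percentage points lower from compound 3 to compound 4 (beyond the scatter) with the hydroxy group kept, so the two compounds differ in ring size alone. The same holds against the ring without a hydroxy group, with a number 15 percentage points lower from compound 2 to compound 4 (beyond the scatter) on going from cyclohexyl to 2-hydroxycycloheptyl, so the hydroxy group on its own does not secure the read-out at this place. Nothing at hand gives a reason for either fall.

Within the data shown here, only two hydroxy-bearing rings appear here, so whether the read-out falls gradually with ring size or only at the seven-membered ring stays open. A 2-hydroxycyclohexyl or a 2-aminocyclopentyl group at this place would bear on that.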